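A few compounds are considered here, and "the series" means these few. Any claim that something is new, unique, unknown or untested is made for them only; others in the source may bear on it.

Measured compounds in an assay on isolated protein for inhibition of cytosolic endo-beta-N-acetylglucosaminidase (Homo sapiens), tested at 1000 uM; on this read-out lower numbers stand for less inhibition and higher numbers for more inhibition at the one concentration tested (going by the name of the read-out):
compound 1, `O=C(O)[C@H]1NC[C@H](O)[C@@H](O)[C@@H]1O`, 43%;
compound 2, `O=C(O)[C@@H]1NC[C@@H](O)[C@@H](O)[C@H]1O`, 26%;
compound 3, `O=C(O)[C@@H]1NC[C@H](O)[C@@H](O)[C@@H]1O`, 5.4%.

Compound 3 stands lowest of the three numbers in this assay: compound 2 lies a number 20.6 percentage points lower from compound 2 to compound 3 (beyond the scatter), and compound 1 lies a number 37.6 percentage points lower from compound 1 to compound 3 (beyond the scatter), so compound 3 is separated from both by more than the scatter. All three compounds share the same atoms and bonds and differ only in configuration as drawn, so every measured step here is a change of configuration alone the fact that compounds 1 and 2 differ only in the configuration as drawn the fact that compounds 1 and 3 differ only in the configuration as drawn (the fact that compounds 2 and 3 differ only in the configuration as drawn).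

Compound 4, `O=C(O)[C@@H]1NC[C@H](O)[C@@H](O)[C@H]1O`, is the next compound to be measured. Its relation to compound 3 is the two compounds have the same atoms and bonds and differ only in configuration as drawn: 1 of 4 stereo elements differ; a stereocentre at a saturated ring carbon is drawn R in compound 3 and S in compound 4. Among the measured compounds shown here, the step that most resembles it is the one from compound 1 to compound 3, where a single stereocentre at a saturated ring carbon was redrawn and the number fell by a number 37.6 percentage points lower from compound 1 to compound 3 (beyond the scatter), a large change. The step from compound 1 to compound 2, with three centres redrawn, gave a modest change of a number 17 percentage points lower from compound 1 to compound 2 (beyond the scatter). A single change of configuration can therefore move this read-out by a modest to large amount, and since compound 3 sits at the bottom of the measured range, the expected direction is upward or no change beyond the scatter. Compound 4 is estimated at 20%, with a range from 3% to 45%, which means an expected step of a number 14.6 percentage points higher from compound 3 to compound 4 (beyond the scatter).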

Compound 4, a percentage reported as inhibition, at one concentration (the size of the read-out at that concentration, not a potency): 42%
For compound 4 the middle estimate is 22 percentage points below the measured one; the range from low to high includes it.
By their numbers in this assay, from the lowest: compound 3; then compound 2; then compounds 4 and 1 (each within the scatter of the next).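

In this assay, redrawing a single stereocentre at a saturated ring carbon gives a number 36.6 percentage points higher from compound 3 to compound 4 (beyond the scatter), which shows that the low number of compound 3 is not fixed by the rest of its configuration and that one centre alone can restore much of the read-out, a change that can only lie in the stereochemistry: the fact that compounds 3 and 4 differ only in the configuration as drawn. Another step with a single centre redrawn, again from R to S at a saturated ring carbon, gives only a number 16 percentage points higher from compound 2 to compound 4 (beyond the scatter), so the size of the effect of one redrawn centre depends on the configuration of the remaining centres. Redrawing two centres at once leaves the read-out unresolved from its earlier level, with a number 1 percentage points lower from compound 1 to compound 4 (within the scatter), so two different arrangements of the shared core can reach the same level of inhibition.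

Going by these compounds, all these numbers come from one high concentration and give no potency, so how far the compounds truly differ in strength stays open. On these data alone, all four also carry the same carboxylic acid and hydroxyl groups, so what a methyl ester or an amide in place of the carboxylic acid would do on the better configurations remains unknown.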